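A few compounds are considered here, and "the series" means these few. Any claim that something is new, unique, unknown or untested is made for them only; others in the source may bear on it.

Measured so far:
compound 1, `O=C(O)CCCCCCCC#CC#CC#CC#C[C@@H](O)CO`, which in a functional assay on KB cells (Homo sapiens) for cytotoxicity, in the absence of a further agent (a lower number here means that less compound is needed, a higher number that more compound is needed for the effect), gives 13.4 ug/mL;
compound 2, `C[C@H](O)C#CC#CC#CC#CCCCCCCCC(=O)O`, which in this assay gives 4.3 ug/mL.

For the measured compounds named here, compound 2 stands lowest of these two numbers in this assay; its only neighbour is compound 1, and the step of a 3.1-fold lower number from compound 1 to compound 2 (0.49 log units; beyond the scatter) lies beyond the scatter. Compound 3, `C[C@H](O)/C=C/C#CC#CC#CCCCCCCCC(=O)O`, differs from compound 2 in one place: 3-hydroxybut-1-en-1-yl in place of 3-hydroxybut-1-yn-1-yl on a triple-bonded carbon. Going by the values given here, no measured step bears directly on this exchange. Among the compounds with values here, the single step known, a 3.1-fold lower number from compound 1 to compound 2 (0.49 log units; beyond the scatter), concerns a hydroxy replaced by hydrogen on a saturated chain carbon, whereas here a 3-hydroxybut-1-yn-1-yl gives way to a 3-hydroxybut-1-en-1-yl on a triple-bonded carbon, so that step offers no guide to direction or size. With nothing pointing one way or the other, the step of a 1.3-fold higher number from compound 2 to compound 3 (0.11 log units; within the scatter) is expected to remain within the scatter, and a wide range is allowed for on either side. Compound 3 is therefore estimated at 5.5 ug/mL in this assay, with a range from 2.2 ug/mL to 14 ug/mL.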

Compound 3, concentration for half-maximal effect: > 20 ug/mL
Compound 3: no number, only a limit; the forecaster's own chance of this, stated with the estimate: 5%; middle value at least 3.6-fold (0.56 log units) from the limit.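

In this assay compound 3 gives > 20 ug/mL, and this is a limit of the assay, not a number: the limit of > 20 ug/mL in this assay, at which 1 of the 3 values shown sits.

The earlier pair spoke only to a hydroxy on a saturated chain carbon, whereas this result shows that the group on the triple-bonded carbon also matters. Exchanging 3-hydroxybut-1-yn-1-yl for 3-hydroxybut-1-en-1-yl, which turns one triple bond into one double bond and leaves the count of heavy atoms, donors and acceptors unchanged, gives an at least 4.6-fold higher number from compound 2 to compound 3 (0.66 log units; beyond the scatter), so more compound is needed once the triple bond in this group is gone. The comparison with the dihydroxy group is less firm, at an at least 1.4-fold higher number from compound 1 to compound 3 (0.17 log units; that floor lies within the scatter), and this floor alone does not establish a real gap between those two compounds.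

As far as these compounds go, how large the loss really is stays open, since only a limit is available for compound 3. Also open, from the compounds shown here alone, is whether a saturated 3-hydroxybutyl group on the same carbon would lose as much, and whether an amine in place of the hydroxy would keep the 3-hydroxybut-1-yn-1-yl result.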